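This account rests on a few compounds, and the source may have more. Where it says the series, first, only, none or still open, it means among the compounds named here.

Three compounds have so far been run in an assay on brain (strain Sprague-Dawley) for displacement of a labelled ligand from sodium-dependent dopamine transporter (Rattus norvegicus), read by scintillation counting, with a stated time of 120 min; on this read-out lower numbers stand for stronger inhibition and higher numbers for weaker inhibition. Compound 1 `NC(=O)C[S+]([O-])C(c1cccc(F)c1)c1cccc(F)c1` gives 5930 nM. Compound 2 `CCCCNC(=O)CSC(c1ccccc1)c1ccccc1` gives 23600 nM, the highest number of the three and thus the weakest inhibition among them; its gap to compound 1 and its wider gap to compound 3 both lie beyond the scatter. Compound 3 `CCCCNCC[S+]([O-])C(c1ccccc1)c1ccccc1` gives 1570 nM, the lowest number of the three.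

Compound 4 `O=C(CSC(c1ccccc1)c1ccccc1)NCCCc1ccccc1` has not yet been measured. It differs from compound 2 in one place: phenyl in place of methyl on a saturated chain carbon, three bonds along the chain from an amide-type nitrogen. Going by the values given here, no pair among the measured compounds differs by this change alone, so nothing measured shows its effect directly. Because compound 2 gives 23600 nM, the highest number in this set, room remains for a lower number, and a modest step toward stronger inhibition is expected, a 2.4-fold lower number from compound 2 to compound 4 (0.37 log units; beyond the scatter), though a step within the scatter would not surprise. Compound 4 is accordingly estimated at 10000 nM, with a range from 3000 nM to 30000 nM.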

Compound 4, inhibition constant: 2020 nM
Compound 4: middle estimate off by 5.0-fold (0.69 log units), on the high side, outside the stated range (below it).
By their numbers in this assay, from the lowest: compounds 3 and 4 (each within the scatter of the next); then compound 1; then compound 2.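

In this assay, going by these compounds alone, phenyl in place of methyl on a saturated chain carbon, three bonds along the chain from an amide-type nitrogen, gives a 12-fold lower number from compound 2 to compound 4 (1.07 log units; beyond the scatter), the first direct reading of this change and a large one. The position therefore accepts the larger group, read one bond further out as butyl to 3-phenylpropyl, and the change goes with stronger inhibition rather than a loss. Nothing available explains the size of this step.

From the compounds shown here alone, it remains open whether the gain depends on the aromatic ring itself or would also come with a longer alkyl chain, a cyclohexyl group or a pyridine ring at this position. Going by these compounds, it is equally open whether 3-phenylpropyl in place of butyl would give a similar step on the core of compound 3.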